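Thiosemicarbazone series: furan-2-yl in place of 3-chlorophenyl

The compounds below may be only part of what the source reports. "The series", "measured", "known", "first", "only" and "open" are said of these compounds alone.

Measured compounds:
compound 1 `CC1=CC[C@H](C(C)(C)NC(=S)NN)CC1`
compound 2 `CC1=CC[C@H](C(C)(C)NC(=S)N/N=C/c2ccccc2)CC1`
compound 3 `CC1=CC[C@H](C(C)(C)NC(=S)N/N=C/c2cccc(Cl)c2)CC1`

In a functional assay on NCI/ADR-RES cells (Homo sapiens) for inhibition, read by sulforhodamine B assay, with a stated time of 48 h (on this read-out higher numbers stand for weaker inhibition of growth and lower numbers for stronger inhibition of growth), compound 1 gives > 100000 nM, which is a limit of the assay and not a number. In this assay compound 2 gives > 100000 nM, again a limit. Compound 3 gives > 100000 nM in this assay, also a limit. Compound 3 thus stands at the limit where every shown value sits, as the limit of > 100000 nM in this assay, at which 3 of the 3 values shown sit, records. The step that the two limits leave unreadable from compound 2 to compound 3 has no readable size.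

Compound 4 `CC1=CC[C@H](C(C)(C)NC(=S)N/N=C/c2ccco2)CC1` differs from compound 3 by furan-2-yl in place of 3-chlorophenyl on a carbon with a double bond to nitrogen. No measured step of readable size bears on this change; all shown values are limits. Compound 4 is expected to give 150000 nM in this assay, within 50000 nM to 500000 nM, most likely again as a limit. The expected step that the limit leaves unreadable from compound 3 to compound 4 is none beyond the scatter.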

Compound 4, concentration for total growth inhibition: 14100 nM
Estimate against measurement, compound 4: 11-fold (1.03 log units) above; measured number below the stated range.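

In this assay, the group on a carbon with a double bond to nitrogen now shows a readable effect: furan-2-yl in place of 3-chlorophenyl gives an at least 7.0-fold lower number from compound 3 to compound 4 (0.85 log units; beyond the scatter), and furan-2-yl in place of phenyl gives an at least 7.0-fold lower number from compound 2 to compound 4 (0.85 log units; beyond the scatter). Against the shared core without that group, the step is an at least 7.0-fold lower number from compound 1 to compound 4 (0.85 log units; beyond the scatter). Compound 4 is the only compound shown that gives a number and not a limit of the assay: the limit of > 100000 nM in this assay, at which 3 of the 4 values shown sit.

Steps between two limits cannot be read, so any effect of chloro in place of hydrogen stays unknown. As far as these compounds go, whether a thiophene or pyridine ring would serve like furan-2-yl remains open.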